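Fluoro in place of methyl on two cores

A few compounds are considered here, and "the series" means these few. Any claim that something is new, unique, unknown or untested is made for them only; others in the source may bear on it.

Compound 1 `Cc1ccc(NC(=O)C(C)Br)cc1C(=O)NC(N)=O` carries a methyl on the aromatic ring together with a ((1-bromoethyl)carbonyl)amino group. In a functional assay on CCRF-CEM cells (Homo sapiens) for antiproliferative activity, read by trypan blue exclusion, with a stated time of 72 h (a lower number here means a stronger inhibitor, a higher number a weaker inhibitor), compound 1 gives only a limit, > 20000 nM, and no number. Compound 2 `CC(Br)C(=O)Nc1ccc(F)c(C(=O)NC(N)=O)c1` differs from compound 1 by fluoro in place of methyl on an aromatic carbon. In this assay compound 2 gives 520 nM, so that the step is an at least 38-fold lower number from compound 1 to compound 2 (1.58 log units; beyond the scatter). The step starts from the limit of > 20000 nM in this assay, at which 1 of the 3 values shown sits, so its full size is not known. Compound 3 `Cc1ccc(C(=O)NC(N)=O)cc1NC(=O)CBr` carries a ((bromomethyl)carbonyl)amino group; how its core differs from that of compound 1 is not broken down here. In this assay compound 3 gives 4280 nM, the higher of the two numbers.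

Compound 4 `NC(=O)NC(=O)c1ccc(F)c(NC(=O)CBr)c1` is not yet measured and differs from compound 3 by fluoro in place of methyl on an aromatic carbon. This is the same kind of change as from compound 1 to compound 2, but the place is not the same: in compound 1 the methyl sits ortho to a carbamoylcarbamoyl group and para to a ((1-bromoethyl)carbonyl)amino group, whereas in compound 3 it sits ortho to a ((bromomethyl)carbonyl)amino group and para to a carbamoylcarbamoyl group. Among the compounds with values here, because the one measured example of the change gave an at least 38-fold lower number from compound 1 to compound 2 (1.58 log units; beyond the scatter), a lowering is expected for compound 4 too. A smaller step is expected, since the surroundings differ and that case rests on a limit, namely a 5.4-fold lower number from compound 3 to compound 4 (0.73 log units; beyond the scatter). Compound 4 is therefore estimated at 800 nM in this assay, with a likely range from 200 nM to 3000 nM.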

Compound 4, half-maximal inhibitory concentration: 2290 nM
Compound 4: middle estimate off by 2.9-fold (0.46 log units), on the low side; the measured number falls inside the stated range.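

In this assay, fluoro in place of methyl on the core of compound 3 gives a 1.9-fold lower number from compound 3 to compound 4 (0.27 log units; within the scatter), so on this core the change produces no shift that can be told apart from repeated measurement. The size of the step therefore does not carry from one core to the other in this pair of examples: the same change on two cores in this assay, an at least 38-fold lower number (1.58 log units; beyond the scatter) from compound 1 to compound 2 and a 1.9-fold lower number (0.27 log units; within the scatter) from compound 3 to compound 4, at least 20-fold (1.31 log units) apart, beyond the scatter of two such steps What this does not show is how large the gap truly is, or which feature of the two cores sets it, since the earlier step starts from the limit of compound 1, its full size is unknown, and only two examples of the change are available: the limit of > 20000 nM in this assay, at which 1 of the 4 values shown sits.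

Open, on these data alone, is how other groups would behave on the same aromatic carbon of either core, for example chloro, methoxy or a plain hydrogen in place of the methyl or the fluoro, which would show whether the large step is particular to fluoro and to the core of compound 1. Also open, as far as these compounds go, is whether the same contrast holds when the carbamoylcarbamoyl group gives way to a carboxylic acid, or when the bromo-bearing acyl chain is replaced by a longer chain.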